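Moving the ethoxy group of compound 3

This account rests on a few compounds, and the source may have more. Where it says the series, first, only, none or still open, it means among the compounds named here.

Measured in a functional assay on HeLa cells (Homo sapiens) for inhibition, read by sulforhodamine B assay; a lower number here means a stronger inhibitor, a higher number a weaker inhibitor:
Compound 1 `O=C1C=C(Nc2ccccc2F)C(=O)c2c1nc1n2[C@H]2OC[C@@H](O)[C@H]2OC1`: 5120 nM
Compound 2 `O=C1C=C(NC2CCCC2)C(=O)c2c1nc1n2[C@H]2OC[C@@H](O)[C@H]2OC1`: > 16000 nM, a limit of the assay
Compound 3 `CCOc1ccc(NC2=CC(=O)c3nc4n(c3C2=O)[C@H]2OC[C@@H](O)[C@H]2OC4)cc1`: 3110 nM

For the measured compounds named here, compound 3 holds one of only two true numbers in this set, and the gap between those two is small: a 1.6-fold lower number from compound 1 to compound 3 (0.22 log units; within the scatter). Swapping a phenyl group for cyclopentyl gave larger steps: an at least 3.1-fold higher number from compound 1 to compound 2 (0.49 log units; beyond the scatter), and an at least 5.1-fold lower number from compound 2 to compound 3 (0.71 log units; beyond the scatter).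

Compound 4 `CCOc1ccccc1NC1=CC(=O)c2nc3n(c2C1=O)[C@H]1OC[C@@H](O)[C@H]1OC3` has the same atoms as compound 3, joined differently: 2-ethoxyphenyl in place of 4-ethoxyphenyl on an amine nitrogen. Going by the values given here, no measured step moves a group around the same ring. The closest guide is the exchange between two phenyl groups, a 1.6-fold lower number from compound 1 to compound 3 (0.22 log units; within the scatter), so no change beyond the scatter is expected. The expected step is a 1.3-fold higher number from compound 3 to compound 4 (0.11 log units; within the scatter). For compound 4 the estimated value is 4000 nM, with an expected range of 1800 nM to 9500 nM.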

Compound 4, half-maximal inhibitory concentration: 6040 nM
Estimate against measurement, compound 4: 1.5-fold (0.18 log units) below; the range from low to high includes it.
By their numbers in this assay, from the lowest: compounds 3, 1 and 4 (each within the scatter of the next). At a limit, above all of these: compound 2.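

In this assay, 2-ethoxyphenyl in place of 4-ethoxyphenyl on the amine nitrogen stayed within the scatter, with a 1.9-fold higher number from compound 3 to compound 4 (0.29 log units; within the scatter), and so did ethoxy in place of fluoro on an aromatic carbon, with a 1.2-fold higher number from compound 1 to compound 4 (0.07 log units; within the scatter). The gap to cyclopentyl held for this third substituted phenyl group as well, with an at least 2.6-fold lower number from compound 2 to compound 4 (0.42 log units; beyond the scatter). Compound 2 carries a limit, not a true number: the limit of > 16000 nM in this assay, at which 1 of the 4 values shown sits.

On these data alone, whether a chain longer than ethoxy would move the number beyond the scatter remains open. The same holds for an amine or a carboxylic acid on the phenyl ring.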